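The source may hold more compounds than are shown below. What is called first, only, known or untested is meant among the compounds shown, and "the series" means these compounds.

Measured compounds in an assay on membranes from brain for displacement of a labelled ligand from Neuronal acetylcholine receptor; alpha4/beta2 (Rattus norvegicus); on this read-out lower numbers stand for stronger inhibition and higher numbers for weaker inhibition:
- compound 1, `c1cnc2[nH]c(C[C@H]3CCCN3)cc2c1`, gives 125 nM
- compound 2, `c1cnc2[nH]c(C[C@@H]3CCCN3)cc2c1`, gives 2750 nM
- compound 3, `CN1CCC[C@H]1Cc1cc2cccnc2[nH]1`, gives 691 nM

Compound 2 stands highest of the three numbers. Nearest is compound 3, reached by a 4.0-fold lower number from compound 2 to compound 3 (0.60 log units; beyond the scatter). Furthest is compound 1: the step of a 22-fold higher number from compound 1 to compound 2 (1.34 log units; beyond the scatter) is large and rests on (the fact that compounds 1 and 2 differ only in the configuration as drawn).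

Compound 4, `Fc1ccc2cc(C[C@@H]3CCCN3)[nH]c2n1`, differs from compound 2 by fluoro in place of hydrogen on an aromatic carbon. Among the measured compounds shown here, neither measured step concerns a substituent on an aromatic carbon, so no direct precedent exists in this set; the change is small and the configuration of compound 2 is kept. The step of a 1.1-fold lower number from compound 2 to compound 4 (0.04 log units; within the scatter) is therefore expected to stay within the scatter. Compound 4 is estimated at 2500 nM, with a range from 800 nM to 8000 nM.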

Compound 4, inhibition constant: 2000 nM
Estimate against measurement, compound 4: 1.3-fold (0.10 log units) above; low and high end bracket the measured number.
By their numbers in this assay, from the lowest: compound 1; then compound 3; then compounds 4 and 2 (each within the scatter of the next).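

Fluoro in place of hydrogen on an aromatic carbon, next to the ring nitrogen, leaves the number in the weaker configuration unmoved (a 1.4-fold lower number from compound 2 to compound 4 (0.14 log units; within the scatter)). Among the compounds shown here, this is the first change on an aromatic carbon, and it shows that this position accepts fluoro without a step beyond the scatter. Nothing measured here accounts for this outcome. Still open, going by these compounds, is whether fluoro reads the same in the configuration of compound 1, and whether chloro, methoxy or an amine at this position does likewise.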